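The source may hold more compounds than are shown below. What is called first, only, known or untested is meant among the compounds shown, and "the series" means these compounds.

In a functional assay on Hep 3B2 cells (Homo sapiens) for cytotoxicity, read by MTT assay (on this read-out higher numbers stand for weaker inhibition and lower numbers for stronger inhibition), compound 1 `COc1ccc(OC)c(C(=O)/C=C/c2ccoc2)c1` gives 12000 nM and compound 2 `COc1ccc(OC)c(C(=O)/C=C/c2cccs2)c1` gives 8400 nM while compound 3 `COc1ccc(OC)c(C(=O)/C=C/c2ccsc2)c1` gives 5700 nM at the low end of the three. Only a 2.1-fold lower number from compound 1 to compound 3 (0.32 log units; beyond the scatter) clears the scatter, whereas a 1.5-fold lower number from compound 2 to compound 3 (0.17 log units; within the scatter) does not. Compound 4 `COc1ccc(OC)c(C(=O)/C=C/c2occc2Br)c1` differs from compound 3 thus: 3-bromofuran-2-yl in place of thiophen-3-yl on a double-bonded chain carbon bound to a double-bonded chain carbon on a double-bonded chain carbon bound to a double-bonded chain carbon. The nearest evidence on trading a furan for a thiophene is a 2.1-fold lower number from compound 1 to compound 3 (0.32 log units; beyond the scatter) read in reverse, alongside a 1.4-fold lower number from compound 1 to compound 2 (0.15 log units; within the scatter) within the scatter. For the measured compounds named here, no measured compound carries bromine, so that part of the change is untested. In this assay the expected step is a 1.3-fold higher number from compound 3 to compound 4 (0.12 log units; within the scatter) and none beyond the scatter is expected. For compound 4 the estimated value is 7500 nM (expected range 2800 nM to 20000 nM).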

Compound 4, half-maximal inhibitory concentration: 11000 nM
The estimate for compound 4 lay 1.5-fold (0.17 log units) below the measured number; the range from low to high includes it.
By their numbers in this assay, from the lowest: compounds 3, 2, 4 and 1 (each within the scatter of the next, the first and the last beyond it).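

In this assay, for the compounds shown here, 3-bromofuran-2-yl is the first bromine-bearing group at this place, and it does not separate from any of the three earlier rings: (a 1.9-fold higher number from compound 3 to compound 4 (0.29 log units; within the scatter)), (a 1.3-fold higher number from compound 2 to compound 4 (0.12 log units; within the scatter)) and (a 1.1-fold lower number from compound 1 to compound 4 (0.04 log units; within the scatter)). Going by these compounds alone, the one step beyond the scatter among the earlier compounds therefore finds no counterpart with compound 4. Within the data shown here, no evidence on these compounds bears on this result.

Bromine and the change of ring arrive together in compound 4, so what bromine alone contributes stays open. Also open, on these data alone, is how an amine or a carboxylic acid on the ring at this place would read.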